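The source may report more compounds than this note shows. Statements on the series, on what has been measured and on what is new or still open speak of the compounds shown alone.

Measured so far in a functional assay (aorta) with Oryctolagus cuniculus as the target; a lower number here means a stronger inhibitor, a higher number a weaker inhibitor:
compound 1 `OCc1ccc(-c2nn(Cc3ccccc3F)c3ncncc23)o1` — 9400 nM
compound 2 `Fc1ccccc1Cn1nc(-c2ccccn2)c2cccnc21` — 4800 nM
compound 3 `CC(C)c1cnc(-c2nn(Cc3ccccc3F)c3ncccc23)nc1N` — 207000 nM

Compound 3 has the highest number of the three in this assay. Both other compounds lie beyond the scatter from it: compound 1 is the nearer of the two, compound 2 the further away. The three measured compounds each differ from one another in more than one place, so no single structural change can be tied to any of these gaps.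

Compound 4 `CSc1cnc(-c2nn(Cc3ccccc3F)c3ncccc23)nc1N` has not yet been measured in this assay. It differs from compound 3 at one place only: methylsulfanyl in place of isopropyl on an aromatic carbon. For the measured compounds named here, no pair of measured compounds shows this exchange, so the numbers give no direct guide to its size or direction. The change is a small one on a substituent of similar bulk, and the expected step is a 1.6-fold lower number from compound 3 to compound 4 (0.20 log units; within the scatter), a modest move toward a lower number that may well stay within the scatter. Compound 4 is therefore expected to give 130000 nM in this assay, with a range of 35000 nM to 500000 nM.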

Compound 4, half-maximal inhibitory concentration: 243000 nM
Compound 4: middle estimate off by 1.9-fold (0.27 log units), on the low side, within the range that was stated.
By their numbers in this assay, from the lowest: compounds 2 and 1 (each within the scatter of the next); then compounds 3 and 4 (each within the scatter of the next).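

In this assay, for the compounds shown here, methylsulfanyl in place of isopropyl on the aromatic carbon ortho to the amino group gives a 1.2-fold higher number from compound 3 to compound 4 (0.07 log units; within the scatter), the first step that can be read at this position. Methylsulfanyl, with its sulfur and its hydrogen-bond acceptor, and isopropyl, with neither, are thus not told apart at this position in this assay. Nothing available accounts for this result.

Both groups carry no ring and no net charge, so the compounds shown do not say how this position would respond to an amine, a carboxylic acid or a longer chain such as hexyl. The part played by the amino group on the same ring also remains open, as no pair of compounds shown differs there alone.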